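A few compounds are considered here, and "the series" means these few. Any claim that something is new, unique, unknown or untested is made for them only; others in the source may bear on it.

Measured so far:
compound 1, `COc1cc(/C=C(\C)C(=O)N2CCC=CC2=O)cc(OC)c1OC`: 10300 nM
compound 2, `CC/C(=C\c1cc(OC)c(OC)c(OC)c1)C(=O)N1CCC=C(Br)C1=O`: 3020 nM

In a functional assay on HCT-116 cells (Homo sapiens) for cytotoxicity, read by MTT assay, with a stated time of 72 h (a higher number here means a weaker inhibitor, a lower number a stronger inhibitor), compound 2 gives the lower of the two numbers; compound 1 sits above it by a gap that lies beyond the scatter. Compound 3, `COc1cc(/C=C(\C)C(=O)N2CCC=C(Br)C2=O)cc(OC)c1OC`, is not yet measured. It differs from compound 2 by hydrogen in place of methyl on a saturated chain carbon bound to a double-bonded chain carbon. Among the measured compounds shown here, no single-change step is known for this kind of change, so the direction is uncertain; a step of about the scatter or a little beyond it, toward a weaker number, is expected as a 1.5-fold higher number from compound 2 to compound 3 (0.17 log units; within the scatter). Compound 3 is estimated at 4500 nM, with a range from 1500 nM to 13000 nM.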

Compound 3, half-maximal inhibitory concentration: 6200 nM
The estimate for compound 3 lay 1.4-fold (0.14 log units) below the measured number; low and high end bracket the measured number.
By their numbers in this assay, from the lowest: compound 2; then compounds 3 and 1 (each within the scatter of the next).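

In this assay the change from ethyl to methyl, hydrogen in place of methyl on a saturated chain carbon bound to a double-bonded chain carbon, gives a 2.1-fold higher number from compound 2 to compound 3 (0.31 log units; beyond the scatter) and so shows a modest response to this chain at this place. Bromo in place of hydrogen on a double-bonded ring carbon gives a 1.7-fold lower number from compound 1 to compound 3 (0.22 log units; within the scatter) and so shows no separation between these two groups with the methyl chain in place. Nothing measured on these compounds accounts for the chain step.

As far as these compounds go, whether a propyl or longer chain at the same place continues the trend remains open, as does whether chloro on the double-bonded ring carbon would separate from bromo or hydrogen.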